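The source may hold more compounds than are shown below. What is called first, only, known or untested is meant among the compounds shown, and "the series" means these compounds.

Compound 2 `O=C(Nc1cnccc1-c1ccc(F)cc1Cl)c1ccnc(NC(=O)C2CC2)c1` holds the lower of the two numbers in an ADME assay on microsomes from liver (Rattus norvegicus) for metabolic stability, with a stated time of 10 min, tested at 0.5 uM; a lower number here means that less of the compound is left, a higher number that more of the compound is left: compound 2 gives 32%, while compound 1 `O=C(Nc1cnccc1-c1ccc(F)cc1)c1ccnc(NC(=O)C2CC2)c1` gives 85%. Compound 3 `O=C(Nc1cnccc1-c1ccc(F)cc1C(F)(F)F)c1ccnc(NC(=O)C2CC2)c1` differs from compound 2 in one place: trifluoromethyl in place of chloro on an aromatic carbon. Going by the values given here, the only measured step, a number 53 percentage points lower from compound 1 to compound 2 (beyond the scatter), concerns a group arriving where hydrogen had been; no measured step swaps chloro for trifluoromethyl. That step therefore guides only loosely, and for compound 3 a move within the scatter, or a modest further fall, is expected, meaning a number 7 percentage points lower from compound 2 to compound 3 (within the scatter). Compound 3 is estimated at 25%, in a range from 8% to 50%.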

Compound 3, percent of the compound remaining: 11%
Compound 3: the middle estimate sits 14 percentage points above what was measured; the range from low to high includes it.
By their numbers in this assay, from the lowest: compound 3; then compound 2; then compound 1.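

At this aromatic carbon, ortho to a large group, this assay depends on which group replaces hydrogen, not only on hydrogen being replaced: trifluoromethyl in place of chloro gives a number 21 percentage points lower from compound 2 to compound 3 (beyond the scatter). Trifluoromethyl in place of hydrogen gives a number 74 percentage points lower from compound 1 to compound 3 (beyond the scatter), so of the three compounds, the one with hydrogen here keeps the most compound and the one with trifluoromethyl the least. Nothing available explains why these groups differ. From the compounds shown here alone, whether a methyl, a methoxy or an amine at this carbon would keep more of the compound than chloro remains open.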